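A Nitrile Enters the Core of a Dioxygenase Inhibitor

This account rests on a few compounds, and the source may have more. Where it says the series, first, only, none or still open, it means among the compounds named here.

Of the compounds shown here, two have so far been measured in an assay for inhibition of Indoleamine 2,3-dioxygenase 1 (Homo sapiens), with stated times of 10 min and 60 min, tested at 100 uM; a lower number here means a weaker effect, a higher number a stronger effect of the compound at the concentration tested. Compound 1 `O=[N+]([O-])c1ccccc1CNc1cccc2[nH]ncc12` is the simpler of the pair; in this assay compound 1 gives 65%. Compound 2 `O=[N+]([O-])c1cc(Cl)ccc1CNc1cc(C(F)(F)F)cc2[nH]ncc12` carries a chloro group and a trifluoromethyl group in addition, and in this assay compound 2 gives 77%. Compound 1 thus stands lowest of the two numbers, and the gap to compound 2 lies beyond the usual scatter. Compound 2 differs from compound 1 at two places, so no single step can be read from that pair.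

Compound 3 `N#Cc1cc(NCc2ccccc2[N+](=O)[O-])c2cn[nH]c2c1` has not been measured. Compared with compound 1 it shows (cyano in place of hydrogen on an aromatic carbon). Among the measured compounds shown here, no measured pair tells what such a change does on this core; the only hint is that compound 2, which carries a large group on the core and gives 77%, sits higher than compound 1. A small rise, or no step beyond the scatter, seems the most likely outcome, so the expected step of a number 5 percentage points higher from compound 1 to compound 3 (within the scatter) is modest. For compound 3 the estimate in this assay is 70%, ranging from 52% to 86%.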

Compound 3, a percentage reported as inhibition, at one concentration (the size of the read-out at that concentration, not a potency): 17%
For compound 3 the middle estimate is 53 percentage points above the measured one; measured number below the stated range.
By their numbers in this assay, from the lowest: compound 3; then compound 1; then compound 2.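

In this assay, among the compounds shown here, cyano in place of hydrogen on an aromatic carbon gives a number 48 percentage points lower from compound 1 to compound 3 (beyond the scatter), the first step that can be read for a single change. It shows that this position, meta to a large group and para to a fused ring, does not accept every addition: a group of only two heavy atoms is enough to remove much of the inhibition seen at the concentration tested. The data shown offer no measurement that explains this drop.

A single group at one position cannot show whether the loss is specific to the nitrile or would follow any substituent placed there, so a methoxy group, an amine or a carboxylic acid at the same carbon would each be a separate test of this position. On these data alone, it also remains open whether cyano would bring a step of similar size on a compound that also carries the chloro group of compound 2.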